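The compounds below may be only part of what the source reports. "The series", "measured", "known", "first", "only" and "open" are said of these compounds alone.

Three compounds sharing one core were tested in a functional assay on DU-145 cells (Homo sapiens) for cytotoxicity, read by sulforhodamine B assay, with a stated time of 2 days, tested at 100 uM; on this read-out higher numbers stand for more inhibition at the one concentration tested (going by the name of the read-out) and lower numbers for less inhibition. Compound 1 `O=C(Nn1c(-c2cccc([N+](=O)[O-])c2)nc2c(-c3ccc(Cl)cc3)n[nH]c2c1=O)c1ccccc1` gives 94.3%, compound 2 `COc1cccc(-c2nc3c(-c4ccc(Cl)cc4)n[nH]c3c(=O)n2NC(=O)c2ccccc2)c1` gives 94.1%, and compound 3 `O=C(Nn1c(-c2ccccc2)nc2c(-c3ccc(Cl)cc3)n[nH]c2c1=O)c1ccccc1` gives 90.2%. Compound 3 holds the lowest of the three numbers, yet its gaps to the others, a number 4.1 percentage points lower from compound 1 to compound 3 (within the scatter) and a number 3.9 percentage points lower from compound 2 to compound 3 (within the scatter), are within the scatter, as is a number 0.2 percentage points lower from compound 1 to compound 2 (within the scatter). Compound 4 `COc1cccc(Cc2nc3c(-c4ccc(Cl)cc4)n[nH]c3c(=O)n2NC(=O)c2ccccc2)c1` differs from compound 3 by 3-methoxybenzyl in place of phenyl on an aromatic carbon. The measured steps only exchange one small group on that phenyl, and the closest of them, a number 3.9 percentage points lower from compound 2 to compound 3 (within the scatter), moved little. Among the measured compounds shown here, no measured pair covers a 3-methoxybenzyl in this place. Compound 4 is therefore expected to remain close, with an estimated step of a number 3.2 percentage points lower from compound 3 to compound 4 (within the scatter), giving an estimate of 87%, ranging from 68% to 96%.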

Compound 4, a percentage reported as inhibition, at one concentration (the size of the read-out at that concentration, not a potency): 93.2%
The estimate for compound 4 lay 6.2 percentage points below the measured number, within the range that was stated.
By their numbers in this assay, from the lowest: compounds 3, 4, 2 and 1 (each within the scatter of the next).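

In this assay, among the compounds shown here, putting 3-methoxybenzyl in place of phenyl gives a number 3 percentage points higher from compound 3 to compound 4 (within the scatter), the first exchange here of the whole group at this position rather than a small group on its phenyl. The comparisons with the substituted phenyls, a number 0.9 percentage points lower from compound 2 to compound 4 (within the scatter) and a number 1.1 percentage points lower from compound 1 to compound 4 (within the scatter), stay equally small, so this larger group leaves the read-out within the scatter. Nothing available explains this result. As far as these compounds go, whether an amine, a carboxylic acid or a plain alkyl chain at this position would also leave the number unchanged remains open.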